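The source may hold more compounds than are shown below. What is called first, only, known or untested is meant among the compounds shown, and "the series" means these compounds.

Measured so far:
Compound 1, `CCN(CCn1cc[n+](C)c1/C=N/O)S(=O)(=O)C(F)(F)F` — in a physicochemical assay for lipophilicity (a higher number here means a more lipophilic compound, a lower number a more polar compound), compound 1 gives -1.03.
Compound 2, `CCCN(CCn1cc[n+](C)c1/C=N/O)S(=O)(=O)C(F)(F)F` — in this assay compound 2 gives -0.69.
Compound 3, `CC(Cn1cc[n+](C)c1/C=N/O)NS(=O)(=O)C(F)(F)F` — in this assay compound 3 gives -0.82.

Compound 1 and compound 2 differ by methyl in place of hydrogen on a saturated chain carbon, two bonds along the chain from a sulfonamide nitrogen. That change gave a number 0.34 log units higher from compound 1 to compound 2 (beyond the scatter). Compound 3 and compound 1 differ in more than one place; the difference between the two cores is not broken down here. Compound 4, `CCC(Cn1cc[n+](C)c1/C=N/O)NS(=O)(=O)C(F)(F)F`, awaits measurement; it differs from compound 3 by methyl in place of hydrogen on a saturated chain carbon, two bonds along the chain from a sulfonamide nitrogen, the same change as between compound 1 and compound 2, at the same place. The step from compound 3 to compound 4 is expected to be of similar size to the earlier one, a number 0.34 log units higher from compound 3 to compound 4 (beyond the scatter), because of a number 0.34 log units higher from compound 1 to compound 2 (beyond the scatter). For compound 4 the estimate in this assay is -0.48, with a range from -0.8 to -0.15.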

Compound 4, distribution coefficient: -0.42
Beside the measured number, compound 4's estimate is 0.06 log units below it; measured number inside the range.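

In this assay methyl in place of hydrogen gave a number 0.40 log units higher from compound 3 to compound 4 (beyond the scatter) on one core and a number 0.34 log units higher from compound 1 to compound 2 (beyond the scatter) on the other, the same direction and both modest. This shows that the step carried from one core to the other in these two pairs, but it does not show that it would carry to any further core or to another place on the chain. Nothing measured here bears on what lies behind the step.

The compounds shown leave open what a longer chain, an amine or a carboxylic acid would do in place of that methyl on either core. They also leave open whether the same step would persist on a further extension from methyl to ethyl at this place.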